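A few compounds are considered here, and "the series" means these few. Any claim that something is new, unique, unknown or untested is made for them only; others in the source may bear on it.

Measured so far: compound 1 `COc1cc(-c2nn(-c3cccc(NC(=O)c4ccc(Cl)c(C(F)(F)F)c4)c3)cc2-c2ccncc2)ccc1Cl` at > 32500 nM; compound 2 `O=C(Nc1cccc(-n2cc(-c3ccncc3)c(-c3ccc(Cl)c(O)c3)n2)c1)Nc1cc(C(F)(F)F)cc(C(F)(F)F)c1` at 3270 nM.

In a functional assay on NCI-H23 cells (Homo sapiens) for inhibition, read by sulforhodamine B assay, with a stated time of 48 h (a higher number here means a weaker inhibitor of growth, a lower number a stronger inhibitor of growth), compound 1 gives > 32500 nM, which is a limit of the assay and not a number (the limit of > 32500 nM in this assay, at which 1 of the 2 values shown sits). In this assay compound 2 gives 3270 nM. Compound 3 `COc1cc(-c2nn(-c3cccc(NC(=O)Nc4cccc(C(F)(F)F)c4)c3)cc2-c2ccncc2)ccc1Cl` is not yet measured. It differs from compound 1 by (3-(trifluoromethyl)phenyl)amino in place of 4-chloro-3-(trifluoromethyl)phenyl on a carbonyl carbon. Among the compounds with values here, no measured step covers this change, so the size of the step from compound 1 to compound 3 is uncertain; a move toward stronger growth inhibition is expected, as an at least 3.6-fold lower number from compound 1 to compound 3 (0.55 log units; beyond the scatter). Compound 3 is estimated at 9000 nM, within 2500 nM to 32500 nM.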

Compound 3, concentration for total growth inhibition: 3410 nM
Estimate against measurement, compound 3: 2.6-fold (0.42 log units) above; the measured number falls inside the stated range.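

In this assay the change on the carbonyl carbon gives an at least 9.5-fold lower number from compound 1 to compound 3 (0.97 log units; beyond the scatter), which shows that growth inhibition responds to this position. Going by these compounds, compound 1 stands at a limit of the assay, so the full size of the step stays unknown: the limit of > 32500 nM in this assay, at which 1 of the 3 values shown sits. The change adds the amino nitrogen, with its hydrogen-bond donor, and removes the chlorine in a single step.

Which of these two differences carries the step remains open. Also open, on these data alone, is what a methylene or an oxygen in place of the amino nitrogen would give.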